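This account rests on a few compounds, and the source may have more. Where it says the series, first, only, none or still open, it means among the compounds named here.

In a functional assay on HL-60 cells (Homo sapiens) for inhibition, read by CCK-8 assay, with a stated time of 48 h (on this read-out higher numbers stand for weaker inhibition and lower numbers for stronger inhibition), compound 1 (`O=C(NCCNS(=O)(=O)c1ccc(-c2ccccc2OCc2cccc(O)c2)s1)Nc1cc(C(F)(F)F)cc(C(F)(F)F)c1`) gives 4000 nM, the lowest number among the three measured compounds. Compound 2 (`O=C(NCCNS(=O)(=O)c1ccc(-c2ccccc2OCc2ccccc2)s1)Nc1cc(Cl)cc(Cl)c1`) gives 11700 nM, a gap beyond the scatter. Compound 3 (`Cc1cc(C)cc(NC(=O)NCCNS(=O)(=O)c2ccc(-c3ccccc3Oc3ccc(N)cc3)s2)c1`) reads > 50000 nM, which is a limit of the assay. Compound 4 (`O=C(NCCNS(=O)(=O)c1ccc(-c2ccccc2OCc2ccccc2)s1)Nc1cc(C(F)(F)F)cc(C(F)(F)F)c1`) keeps the rest of compound 1 but has hydrogen in place of hydroxy on an aromatic carbon, turning (3-hydroxybenzyl)oxy into benzyloxy: hydrogen in place of hydroxy on an aromatic carbon. Within the data shown here, no measured pair isolates this change, so only a small move toward weaker inhibition in this assay is expected, perhaps not beyond the scatter. Compound 2, which also carries benzyloxy, sits at 11700 nM. The expected change is a 1.5-fold higher number from compound 1 to compound 4 (0.18 log units; within the scatter). For compound 4 the estimated value is 6000 nM, with an expected range of 2500 nM to 15000 nM.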

Compound 4, half-maximal inhibitory concentration: 11400 nM
The estimate for compound 4 lay 1.9-fold (0.28 log units) below the measured number, within the range that was stated.
By their numbers in this assay, from the lowest: compound 1; then compounds 4 and 2 (each within the scatter of the next). At a limit, above all of these: compound 3.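

In this assay, among these compounds, hydrogen in place of hydroxy on the 3-hydroxybenzyl group gives a 2.9-fold higher number from compound 1 to compound 4 (0.45 log units; beyond the scatter) and this pair is the first to isolate a single change at this place. The hydroxy on this ring therefore goes with stronger inhibition, by a modest step beyond the scatter. Nothing measured here gives a reason for this step.

As far as these compounds go, whether hydroxy itself is needed stays open, as an amine or a methoxy group at this place could match it or fall short. The compounds shown also leave open how a hydroxy elsewhere on this ring would read.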